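This account rests on a few compounds, and the source may have more. Where it says the series, first, only, none or still open, it means among the compounds named here.

Compound 1, `O=C1CC(c2ccccc2OCc2ccccc2)Oc2ccccc21`, gives 91.5% in a functional assay on J774.A1 cells (Mus musculus) for inhibition, read by immunoassay, with a stated time of 12 h, tested at 30 uM; on this read-out higher numbers stand for more inhibition at the one concentration tested (going by the name of the read-out) and lower numbers for less inhibition.
Compound 2, `CC(C)=CCOc1ccccc1C1CC(=O)c2ccccc2O1`, gives 40.3% in this assay.
Compound 3, `O=C1CC(c2ccccc2OCc2ccc(F)cc2)Oc2ccccc21`, gives 42.1% in this assay.

Compound 3 stands second highest of the three numbers. Its nearest neighbour is compound 2: the step of a number 1.8 percentage points higher from compound 2 to compound 3 (within the scatter) lies within the scatter. Its furthest is compound 1: the step of a number 49.4 percentage points lower from compound 1 to compound 3 (beyond the scatter) is large and beyond the scatter.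

Compound 4, `CCOc1ccccc1C1CC(=O)c2ccccc2O1`, is not yet measured. Its difference from compound 3 is methyl in place of 4-fluorophenyl on a saturated chain carbon bound to an oxygen on an aromatic ring.

Two measured steps act at the same place. The step of a number 51.2 percentage points lower from compound 1 to compound 2 (beyond the scatter) shows that exchanging the phenyl there for a chain group costs much of the inhibition. The step of a number 1.8 percentage points higher from compound 2 to compound 3 (within the scatter) shows that a chain group and the 4-fluorophenyl end up near each other. Within the data shown here, a methyl at this place has no direct precedent, so an estimate can rest only on the observation that every change away from the phenyl of compound 1 has landed in the same lower region. Compound 4 is therefore expected to stay close to compound 3, with at most a modest fall, as the step of a number 7.1 percentage points lower from compound 3 to compound 4 (within the scatter) expresses. For compound 4 the estimate in this assay is 35%, with a range from 10% to 65%.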

Compound 4, a percentage reported as inhibition, at one concentration (the size of the read-out at that concentration, not a potency): 27.7%
Estimate against measurement, compound 4: 7.3 percentage points above, and the stated range covers the measured number.
By their numbers in this assay, from the lowest: compound 4; then compounds 2 and 3 (each within the scatter of the next); then compound 1.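

Exchanging the 4-fluorophenyl for methyl on the saturated chain carbon gives a number 14.4 percentage points lower from compound 3 to compound 4 (beyond the scatter) in this assay and exchanging the 2-methylprop-1-en-1-yl for methyl gives a number 12.6 percentage points lower from compound 2 to compound 4 (beyond the scatter) at this same place. The level shared by compounds 2 and 3 is thus not a floor for this place. The earlier compounds shown here could have suggested that any group other than the unsubstituted phenyl gives much the same result, but methyl now separates from both of those groups and compound 4 is the lowest of the four. The full exchange of phenyl for methyl, a number 63.8 percentage points lower from compound 1 to compound 4 (beyond the scatter) is the largest step in the set, yet this is no simple trend with group size, as compound 3 keeps a ring at this place and still shows a number 49.4 percentage points lower from compound 1 to compound 3 (beyond the scatter) in the same read-out.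

As far as these compounds go, it remains open whether a longer chain, an amine or a carboxylic acid at this place, or a chloro or methoxy group on the phenyl ring in place of the fluoro, would restore the level of compound 1. Nothing given here explains why these groups differ in inhibition, and no supporting measurement bears on the result.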